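Ether Substituent Variation in a Cathepsin S Inhibitor Series

The compounds below may be only part of what the source reports. "The series", "measured", "known", "first", "only" and "open" are said of these compounds alone.

Measured compounds:
Compound 1, `CC(C)C[C@H](NC(=O)OCc1ccccc1)C(=O)NCCNc1ccc(OC2CCCC2)cc1`, gives 4400 nM.
Compound 2, `CC(C)C[C@H](NC(=O)OCc1ccccc1)C(=O)NCCNc1ccc(OCC2CC2)cc1`, gives 2800 nM.

Both compounds were tested in an assay on isolated protein for inhibition of cathepsin S (Homo sapiens); a higher number here means a weaker inhibitor, a lower number a stronger inhibitor. Compound 1 and compound 2 share a common core and differ only in the group on the oxygen on the aromatic ring. Going by the values given here, the single measured step, a 1.6-fold lower number from compound 1 to compound 2 (0.20 log units; within the scatter), is within the scatter, so compound 2 stands alongside compound 1 and neither number can be said to differ from the other.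

Compound 3, `CC(C)C[C@H](NC(=O)OCc1ccccc1)C(=O)NCCNc1ccc(Oc2ccccc2)cc1`, has not yet been measured. It is derived from compound 2 by the change (phenyl in place of cyclopropylmethyl on an oxygen on an aromatic ring). Among the compounds with values here, the only measured step that bears on this change is the one from compound 1 to compound 2, which also altered the group on the oxygen on the aromatic ring and stayed within the scatter. On that evidence alone, the replacement in compound 3 is expected to give a number in this assay close to that of compound 2, with no step beyond the scatter, expressed as a 1.1-fold lower number from compound 2 to compound 3 (0.05 log units; within the scatter). The estimate for compound 3 in this assay is therefore 2500 nM, with a range from 800 nM to 8000 nM.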

Compound 3, half-maximal inhibitory concentration: 5800 nM
Estimate against measurement, compound 3: 2.3-fold (0.37 log units) below, and the stated range covers the measured number.
By their numbers in this assay, from the lowest: compounds 2, 1 and 3 (each within the scatter of the next, the first and the last beyond it).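

In this assay, the group on an oxygen on an aromatic ring now shows a step beyond the scatter, though only a modest one, with a 2.1-fold higher number from compound 2 to compound 3 (0.32 log units; beyond the scatter) when phenyl replaces cyclopropylmethyl. The other new step, a 1.3-fold higher number from compound 1 to compound 3 (0.12 log units; within the scatter) when phenyl replaces cyclopentyl, stays within the scatter, so these two groups cannot be told apart at this position, and compound 1 lies within the scatter of both compound 2 and compound 3. Thus, among these three ethers, only compound 2 and compound 3 separate, and no supporting measurement bears on why this pair separates while the others do not.

The compounds shown leave open whether a group of another kind on this oxygen, such as a chain carrying an amine or a carboxylic acid, or a longer straight alkyl chain, would give a step larger than any seen here. They also leave open whether a fluorine or a methoxy group on the entering phenyl would shift the number, and whether the step from cyclopropylmethyl to phenyl would hold on a different core.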